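Swapping fluoro for difluoroethyl on a thiazolidinone amide

The source may hold more compounds than are shown below. What is called first, only, known or untested is meant among the compounds shown, and "the series" means these compounds.

Compound 1 `O=C(NCCCCc1ccccc1)c1cccc(C2SCC(=O)N2c2cccc(F)c2)c1` has the higher of the two numbers shown. In a functional assay on SJSA-1 cells (Homo sapiens) for inhibition, read by CCK-8 assay, with a stated time of 72 h, tested at 1 uM (a higher number here means more inhibition at the concentration tested (going by the name of the read-out), a lower number less inhibition), compound 1 gives 80%, while compound 2 `O=C(NCCCCc1ccccc1)c1cccc(C2OCC(=O)N2c2cccc(F)c2)c1` gives 32%, a gap beyond the usual scatter. Compound 3 `CC(F)(F)c1cccc(N2C(=O)CSC2c2cccc(C(=O)NCCCCc3ccccc3)c2)c1` differs from compound 1 in one respect: 1,1-difluoroethyl in place of fluoro on an aromatic carbon. Among the measured compounds shown here, no step between measured compounds with a single change is available to guide this move. The step from compound 1 to compound 3 is expected to be small, a number 12 percentage points lower from compound 1 to compound 3 (beyond the scatter), a modest loss at most. Compound 3 is estimated at 68%, within 40% to 88%.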

Compound 3, a percentage reported as inhibition, at one concentration (the size of the read-out at that concentration, not a potency): 68%
Beside the measured number, compound 3's estimate shows no gap at the digits printed; the measured number falls inside the stated range.
By their numbers in this assay, from the lowest: compound 2; then compound 3; then compound 1.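

In this assay, replacing fluoro with 1,1-difluoroethyl on this aromatic carbon, meta to a large group, gives a number 12 percentage points lower from compound 1 to compound 3 (beyond the scatter). The position therefore takes the larger group with a real but partial loss, leaving compound 3 at 68%. Nothing shown here explains that loss. On these data alone, whether an amine, a methoxy group or a carboxylic acid at this position would hold or raise the number remains open, as does whether 1,1-difluoroethyl would have a similar effect on the core of compound 2.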